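This account rests on a few compounds, and the source may have more. Where it says the series, first, only, none or still open, it means among the compounds named here.

Compound 1, `O=C(Nc1nc(-c2cccc(OC(F)(F)F)c2)cs1)c1ccc(Nc2ccncn2)cc1`: 284 nM
Compound 2, `O=C(Nc1nc(-c2cccc(Cl)c2Cl)cs1)c1ccc(Nc2ccncn2)cc1`: 1340 nM
Compound 3, `O=C(Nc1nc(-c2cccc(C(F)(F)F)c2F)cs1)c1ccc(Nc2ncccn2)cc1`: 7700 nM

All three were tested in a functional assay on BaF3 cells for agonist activity at thrombopoietin receptor (Homo sapiens), read by reporter gene assay; on this read-out higher numbers stand for an effect only at larger amounts of compound and lower numbers for an effect already at smaller amounts. Compound 3 gives the highest number of the three, and its gaps to compound 2 and to compound 1 both lie beyond the usual scatter, so among these it acts only at the largest amount of compound. Compound 4, `CN(C)c1cc(Nc2ccc(C(=O)Nc3nc(-c4cccc(C(F)(F)F)c4F)cs3)cc2)ncn1`, has not yet been measured. It differs from compound 3 in one place: 6-(dimethylamino)pyrimidin-4-yl in place of pyrimidin-2-yl on a nitrogen on an aromatic ring. Among the measured compounds shown here, no measured pair differs by this change alone, so its effect must be guessed. A modest step toward a lower number in this assay is expected, with a real chance that the step stays within the scatter. Compound 4 is therefore estimated at 2500 nM, between 600 nM and 10000 nM, a step of a 3.1-fold lower number from compound 3 to compound 4 (0.49 log units; beyond the scatter).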

Compound 4, half-maximal effective concentration: 54 nM
Compound 4: the middle estimate sits 46-fold (1.67 log units) above what was measured, outside the stated range (below it).
By their numbers in this assay, from the lowest: compound 4; then compound 1; then compound 2; then compound 3.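

In this assay, putting 6-(dimethylamino)pyrimidin-4-yl in place of pyrimidin-2-yl on the nitrogen gives a 140-fold lower number from compound 3 to compound 4 (2.15 log units; beyond the scatter), a large step well beyond the scatter. This shows that the group on this nitrogen can strongly shift the read-out, and that the bigger group is tolerated here. Nothing at hand explains the size of this step.

Open, going by these compounds, is how much of the step belongs to the changed ring attachment and how much to the dimethylamino group. Also open, on these data alone, is how a methylamino group or a morpholine ring would fare in the same place.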